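Acid tail swap in a shared core: compound 4

The source may report more compounds than this note shows. Statements on the series, on what has been measured and on what is new or still open speak of the compounds shown alone.

Measured so far in a functional assay on CHO cells for agonist activity at Free fatty acid receptor 1 (Homo sapiens), read by a luciferase reporter; a higher number here means a larger maximal response, a lower number a smaller maximal response:
- compound 1 `Cc1nc(-c2ccc(C(F)(F)F)cc2)sc1CNc1ccc(CCC(=O)O)cc1` gives 108%
- compound 2 `Cc1nc(-c2ccc(C(F)(F)F)cc2)sc1CNc1ccc(CCCC(=O)O)cc1` gives 44%
- compound 3 `O=C(O)COc1ccc(NCc2cccc(Oc3ccccc3)c2)cc1` gives 84%

Compound 1 stands highest of the three numbers. Its nearest neighbour is compound 3, lower by a margin beyond the scatter; compound 2 is furthest, lower by a large margin.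

Compound 4 `Cc1nc(-c2ccc(C(F)(F)F)cc2)sc1CNc1ccc(OCC(=O)O)cc1` has not yet been measured in this assay. It keeps the core of compound 1 and differs only in the acid tail: carboxymethoxy in place of 2-carboxyethyl on an aromatic carbon.

Within the data shown here, one measured step bears on this tail. a number 64 percentage points lower from compound 1 to compound 2 (beyond the scatter): adding one chain carbon to the acid tail cost most of the response. The change to compound 4 does not lengthen the tail; the count of heavy atoms stays the same, with an oxygen taking the place of a chain carbon. Among the measured compounds shown here, no measured step of exactly this kind exists. Compound 3, which carries the carboxymethoxy tail on a different remainder, gives 84%, below compound 1 but far above compound 2.

A moderate decrease is therefore expected for compound 4, a number 23 percentage points lower from compound 1 to compound 4 (beyond the scatter), smaller than the loss on chain lengthening. The estimate for compound 4 in this assay is 85%, with a range of 55% to 110%.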

Compound 4, largest response reached (reported as percent of maximum), in percent of the reference or control that the assay uses: 100%
For compound 4 the middle estimate is 15 percentage points below the measured one, and the stated range covers the measured number.
By their numbers in this assay, from the lowest: compound 2; then compound 3; then compounds 4 and 1 (each within the scatter of the next).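

In this assay, carboxymethoxy in place of 2-carboxyethyl on this aromatic carbon, para to a large group, gives a number 8 percentage points lower from compound 1 to compound 4 (within the scatter), so on the shared core this exchange of tails leaves no change in maximal response that can be told from the scatter. Set against the longer tail, the same carboxymethoxy group gives a number 56 percentage points higher from compound 2 to compound 4 (beyond the scatter), which leaves 3-carboxypropyl as the only one of the three tails on this core with a clearly reduced response. The numbers come with no evidence that would explain the differences between these tails.

Open, as far as these compounds go, is whether the carboxymethoxy tail tolerates lengthening any better than the all-carbon tail, as a 3-carboxypropoxy group on the same aromatic carbon would show. Also open, from the compounds shown here alone, is whether the response at this position depends on the carboxylic acid itself, which a tetrazole or an acyl sulfonamide at the end of the tail would test, and whether a methyl group on the chain carbon of carboxymethoxy would be accepted.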